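From 2-Methoxybenzyl to 2-Aminobenzyl: Expectations for Compound 4

This account rests on a few compounds, and the source may have more. Where it says the series, first, only, none or still open, it means among the compounds named here.

Of the compounds shown here, three sharing one core have been tested in a functional assay on P388 cells (Mus musculus) for cytotoxicity; on this read-out higher numbers stand for weaker inhibition and lower numbers for stronger inhibition. Compound 1 (`Cc1cc(-c2c(F)cc3c(=O)c(Cc4ccc(Cl)cc4)cn(C4CC4)c3c2F)cc(C)n1`) gives 20000 nM, compound 2 (`COc1ccc(Cc2cn(C3CC3)c3c(F)c(-c4cc(C)nc(C)c4)c(F)cc3c2=O)cc1`) gives 21000 nM, and compound 3 (`COc1ccccc1Cc1cn(C2CC2)c2c(F)c(-c3cc(C)nc(C)c3)c(F)cc2c1=O`) gives 37000 nM. All three values lie within the scatter of one another, so compound 3 cannot be told apart from the other two.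

Compound 4 (`Cc1cc(-c2c(F)cc3c(=O)c(Cc4ccccc4N)cn(C4CC4)c3c2F)cc(C)n1`) has amino in place of methoxy on an aromatic carbon, ortho to a large group: amino in place of methoxy on an aromatic carbon.

For the measured compounds named here, no measured step introduces an amino group, so the evidence is only indirect. Going by the values given here, three steps bear on the change. Methoxy in place of chloro gave a 1.1-fold higher number from compound 1 to compound 2 (0.02 log units; within the scatter), 2-methoxyphenyl in place of 4-methoxyphenyl gave a 1.8-fold higher number from compound 2 to compound 3 (0.25 log units; within the scatter), and 2-methoxyphenyl in place of 4-chlorophenyl gave a 1.9-fold higher number from compound 1 to compound 3 (0.27 log units; within the scatter). Each of these stayed within the scatter. Starting from compound 3 at 37000 nM and these small steps, no step beyond the scatter is expected in this assay, and no direction can be firmly predicted. The estimated change is a 1.4-fold lower number from compound 3 to compound 4 (0.14 log units; within the scatter), which is expected to remain within the scatter. Compound 4 is estimated at 27000 nM, with an expected range from 11000 nM to 60000 nM.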

Compound 4, half-maximal inhibitory concentration: 2100 nM
Compound 4: the middle estimate sits 13-fold (1.11 log units) above what was measured, and the stated range ends above it.
By their numbers in this assay, from the lowest: compound 4; then compounds 1, 2 and 3 (each within the scatter of the next).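

In this assay, for the compounds shown here, the change from 2-methoxybenzyl to 2-aminobenzyl gives an 18-fold lower number from compound 3 to compound 4 (1.25 log units; beyond the scatter) and is the first step to lie beyond the scatter, so this place on an aromatic carbon, ortho to a large group, can strongly affect the read-out when the group on it changes. The earlier swaps among chloro and methoxy benzyl groups could not show this, whereas compound 4 also stands clear of both other compounds, with a 10-fold lower number from compound 2 to compound 4 (1.00 log units; beyond the scatter) and with a 9.5-fold lower number from compound 1 to compound 4 (0.98 log units; beyond the scatter) as well, so the amino compound is the only one that separates from the rest. The swap replaces methoxy, with 0 hydrogen-bond donors, by amino, with 1 hydrogen-bond donor, but nothing measured here shows whether that difference is what matters.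

On these data alone, it remains open whether other groups at this same place, such as a hydroxyl, a methylamino group or an acetamide, would behave like amino or like methoxy. Also open is whether an amino group on another carbon of this ring would give a similar step, since only one amino compound is shown.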